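A few compounds are considered here, and "the series" means these few. Any claim that something is new, unique, unknown or untested is made for them only; others in the source may bear on it.

Measured compounds:
compound 1 `CC[C@@H]1C(=O)N(C)c2cnc(Nc3ccc(S(N)(=O)=O)cc3)nc2N1C1CCCC1`: 1300 nM
compound 2 `CC[C@@H]1C(=O)N(C)c2cnc(-n3ccc4cc(C(=O)NC(C)C)ccc43)nc2N1C1CCCC1`: 1660 nM

In a functional assay on Huh-7 cells (Homo sapiens) for antiproliferative activity, read by CCK-8 assay, with a stated time of 72 h (on this read-out lower numbers stand for stronger inhibition of growth and higher numbers for weaker inhibition of growth), compound 2 has the higher of the two numbers, yet its gap to compound 1 is within the scatter, so no order between the two can be read. Compound 3 `CCNC(=O)c1ccc2c(ccn2-c2ncc3c(n2)N(C2CCCC2)[C@H](CC)C(=O)N3C)c1` is the one not yet measured. It differs from compound 2 by hydrogen in place of methyl on a saturated chain carbon bound to an amide-type nitrogen and a saturated chain carbon. Among the measured compounds shown here, no step between measured compounds is in hand for a change of this kind; with only a hydrogen entering for a methyl, the step from compound 2 to compound 3 in this assay is expected to be none beyond the scatter. Compound 3 is therefore expected near 1500 nM, with a range of 700 nM to 3300 nM. The step this expectation means is a 1.1-fold lower number from compound 2 to compound 3 (0.04 log units; within the scatter).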

Compound 3, concentration for 50% growth inhibition: 596 nM
Compound 3: middle estimate off by 2.5-fold (0.40 log units), on the high side, outside the stated range (below it).
By their numbers in this assay, from the lowest: compound 3; then compounds 1 and 2 (each within the scatter of the next).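

In this assay, the amide substituent proves sensitive: going from isopropylcarbamoyl to ethylcarbamoyl, with hydrogen in place of methyl on the saturated chain carbon bound to an amide-type nitrogen, gives a 2.8-fold lower number from compound 2 to compound 3 (0.44 log units; beyond the scatter) on the shared core. Removing a single methyl at this place is thus enough to move the read-out, although this rests on one pair only. No data in hand account for this step. Still open, as far as these compounds go, is whether the step continues to methylcarbamoyl or the unsubstituted carboxamide. From the compounds shown here alone, a longer chain, or a chain carrying an amine or a carboxylic acid, also remains untested here.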